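A few compounds are considered here, and "the series" means these few. Any claim that something is new, unique, unknown or untested is made for them only; others in the source may bear on it.

Working notes on the series. Compound 1 `Cc1ccc(Nc2ncc3c(n2)N(C)C(=O)N(c2cc(NC(=O)c4cccc(C(F)(F)F)c4)ccc2C)C3)cc1C` and compound 2 `Cc1ccc(Nc2ncc3c(n2)N(C)C(=O)N(c2cc(NC(=O)c4cccc(C(F)(F)F)c4)ccc2C)C3)cc1` share one core and differ at one aromatic carbon. In an ADME assay on BaF3 cells (Mus musculus) for antiproliferative activity, read by CellTiter-Glo and CCK-8 assay, with a stated time of 72 h (a higher number here means a weaker inhibitor of growth, a lower number a stronger inhibitor of growth), compound 1 gives 3760 nM, while compound 2 gives 8000 nM; the change is a 2.1-fold higher number from compound 1 to compound 2 (0.33 log units; beyond the scatter). Compound 2 therefore stands at the highest of the two numbers in this assay, with compound 1 as its nearest neighbour.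

Compound 3 `Cc1ccc(NC(=O)c2cccc(C(F)(F)F)c2)cc1N1Cc2cnc(Nc3ccc(C)c(C(F)(F)F)c3)nc2N(C)C1=O` is not yet measured. It differs from compound 2 by trifluoromethyl in place of hydrogen on an aromatic carbon. Among the compounds with values here, the one measured step that bears on this position is a 2.1-fold higher number from compound 1 to compound 2 (0.33 log units; beyond the scatter), where loss of a small group there raised the number modestly. A substituent at the same place in compound 3 is thus expected to move the number in the opposite direction, by a 2.7-fold lower number from compound 2 to compound 3 (0.43 log units; beyond the scatter), a modest step beyond the scatter. Compound 3 is estimated at 3000 nM in this assay, within 1200 nM to 7500 nM.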

Compound 3, concentration for 50% growth inhibition: > 10000 nM
Compound 3 was reported as a limit; the forecaster's own chance of this, stated with the estimate: 2%; middle value at least 3.3-fold (0.52 log units) away from the limit.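

In this assay the reading of compound 3 is a limit and not a number: the limit of > 10000 nM in this assay, at which 1 of the 3 values shown sits. Trifluoromethyl on this aromatic carbon does not reproduce what methyl does there: the change gives an at least 2.6-fold higher number from compound 1 to compound 3 (0.42 log units; beyond the scatter), so the two groups are separated beyond the scatter, and the lower number seen with methyl does not carry over to trifluoromethyl. Against hydrogen the change gives an at least 1.2-fold higher number from compound 2 to compound 3 (0.09 log units; that floor lies within the scatter), a floor that does not separate the two compounds beyond the scatter.

The limit leaves open how far compound 3 actually lies from compound 2. Also open, as far as these compounds go, is whether a chlorine atom, a methoxy group or an amine on the same carbon would keep the number of compound 1 or behave like trifluoromethyl.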